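Replacing the oxygen substituent of compound 3

A few compounds are considered here, and "the series" means these few. Any claim that something is new, unique, unknown or untested is made for them only; others in the source may bear on it.

Measured in a functional assay on HCT-116 cells (Homo sapiens) for cytotoxicity, read by MTT assay, with a stated time of 72 h; a lower number here means a stronger inhibitor, a higher number a weaker inhibitor:
compound 1 `CN1CCCCC1CCO/N=C1C(=C2/C(=O)Nc3ccc(F)cc32)/Nc2ccccc2/1`: 600 nM
compound 2 `CN(C)CCCO/N=C1C(=C2/C(=O)Nc3ccccc32)/Nc2ccccc2/1`: 710 nM
compound 3 `CN1CCCC1CCO/N=C1C(=C2/C(=O)Nc3ccccc32)/Nc2ccccc2/1`: 370 nM

Compound 3 at 370 nM lies within the scatter of both compound 1 and compound 2, so the numbers do not separate it from either. Compound 4 `CN1CCC(O/N=C2C(=C3/C(=O)Nc4ccccc43)/Nc3ccccc3/2)CC1` differs from it by one change: 1-methylpiperidin-4-yl in place of 2-(1-methylpyrrolidin-2-yl)ethyl on an oxygen. Among the compounds with values here, the one measured step that bears on this, a 1.9-fold lower number from compound 2 to compound 3 (0.28 log units; within the scatter), also alters the group carried on the oxygen, and it stays within the scatter. Within the data shown here, no measured compound carries 1-methylpiperidin-4-yl, so in this assay no shift beyond the scatter is expected. The expected outcome is an estimated 1.4-fold higher number from compound 3 to compound 4 (0.13 log units; within the scatter). Compound 4 is estimated at 500 nM, with an expected range from 200 nM to 1300 nM.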

Compound 4, half-maximal inhibitory concentration: 390 nM
Compound 4: middle estimate off by 1.3-fold (0.11 log units), on the high side; the range from low to high includes it.
By their numbers in this assay, from the lowest: compounds 3, 4, 1 and 2 (each within the scatter of the next).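

In this assay putting 1-methylpiperidin-4-yl on the oxygen gives a 1.1-fold higher number from compound 3 to compound 4 (0.02 log units; within the scatter) and a 1.8-fold lower number from compound 2 to compound 4 (0.26 log units; within the scatter) and so shows that this position can carry a six-membered ring. The numbers do not separate that group from 2-(1-methylpyrrolidin-2-yl)ethyl or 3-(dimethylamino)propyl. No evidence at hand accounts for this result.

The compounds shown leave open what happens on this oxygen with a group lacking an amine, such as a plain methyl or a 2-hydroxyethyl. They also leave open whether a carboxylic acid at the end of a longer chain would stay within the same scatter.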